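This account rests on a few compounds, and the source may have more. Where it says the series, first, only, none or still open, it means among the compounds named here.

Three measured compounds share one core and differ in a single group. In a functional assay (blood) for inhibition, with Homo sapiens as the target (on this read-out lower numbers stand for stronger inhibition and higher numbers for weaker inhibition), compound 3 `COC(=O)c1cc(-c2ccccc2)c2ccc(OCc3cccc(C4(O)CCOCC4)c3)cc2c1` carries methoxycarbonyl and gives 100 nM while compound 2 `COCc1cc(-c2ccccc2)c2ccc(OCc3cccc(C4(O)CCOCC4)c3)cc2c1` carries methoxymethyl and gives 200 nM and the two sit close together (a 2.0-fold lower number from compound 2 to compound 3 (0.30 log units; within the scatter)). Compound 1 `CC(O)c1cc(-c2ccccc2)c2ccc(OCc3cccc(C4(O)CCOCC4)c3)cc2c1` carries 1-hydroxyethyl and gives 675 nM and it stands apart from both (a 6.8-fold lower number from compound 1 to compound 3 (0.83 log units; beyond the scatter) and a 3.4-fold lower number from compound 1 to compound 2 (0.53 log units; beyond the scatter)). Compound 4 `OC1(c2cccc(COc3ccc4c(-c5ccccc5)cc(-c5nn[nH]n5)cc4c3)c2)CCOCC1` has 2H-tetrazol-5-yl in place of the methoxycarbonyl of compound 3 (2H-tetrazol-5-yl in place of methoxycarbonyl on an aromatic carbon). Among the compounds with values here, no measured compound carries this group, so the measured steps offer only a rough guide to size. The 2H-tetrazol-5-yl group holds a hydrogen-bond donor, as the 1-hydroxyethyl group of compound 1 at 675 nM also does, so a modest step towards a higher number is expected in this assay rather than a lower one. The estimated change is a 3.0-fold higher number from compound 3 to compound 4 (0.48 log units; beyond the scatter) for this pair. For compound 4 the estimated value is 300 nM with an expected range from 80 nM to 1000 nM across repeated measurements.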

Compound 4, half-maximal inhibitory concentration: > 3000 nM
Compound 4 gave a limit, no number; the forecaster's own chance of this, stated with the estimate: 3%; at least 10-fold (1.00 log units) between middle value and limit.
By their numbers in this assay, from the lowest: compounds 3 and 2 (each within the scatter of the next); then compound 1. At a limit, above all of these: compound 4.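

In this assay compound 4 gives only a limit, not a number: the limit of > 3000 nM in this assay, at which 1 of the 4 values shown sits. Placing 2H-tetrazol-5-yl at this position produces far larger steps than any among the earlier groups: an at least 30-fold higher number from compound 3 to compound 4 (1.47 log units; beyond the scatter), and an at least 15-fold higher number from compound 2 to compound 4 (1.17 log units; beyond the scatter). Even 1-hydroxyethyl, the one earlier group that holds a hydrogen-bond donor, gives a lower number, with an at least 4.4-fold higher number from compound 1 to compound 4 (0.64 log units; beyond the scatter), so the presence of a donor alone does not tell how far the number will climb.

Going by these compounds, the true size of these steps remains open, since compound 4 has only a limit. On these data alone, it is also open whether the loss goes with the ring or with its donor hydrogen, a question that a tetrazole with a methyl group on a ring nitrogen, or a carboxylic acid, could help to settle.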